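Thienyl-thiophene sulfonamide on the enyne series

The source may hold more compounds than are shown below. What is called first, only, known or untested is meant among the compounds shown, and "the series" means these compounds.

Going by the values given here, compound 2 `CCN(C/C=C/C#CC(C)(C)C)Cc1cccc(OCCN(C)S(=O)(=O)c2cc3ccccc3s2)c1` stands at the top of the two numbers so far recorded in a functional assay on HepG2 cells for inhibition of squalene monooxygenase (Homo sapiens); a higher number here means a weaker inhibitor, a lower number a stronger inhibitor: in this assay compound 2 gives 1800 nM, whereas compound 1 `CCN(C/C=C/C#CC(C)(C)C)Cc1cccc(OCCN(C)S(=O)(=O)Cc2cccs2)c1` gives 200 nM. Among the compounds with values here, the only measured step, a 9.0-fold higher number from compound 1 to compound 2 (0.95 log units; beyond the scatter), replaced a thienylmethyl group on the sulfonyl sulfur with a fused bicyclic aryl group attached directly to it.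

Compound 3 `CCN(C/C=C/C#CC(C)(C)C)Cc1cccc(OCCN(C)S(=O)(=O)c2ccc(-c3ccsc3)s2)c1` keeps a directly attached aromatic group on the sulfonyl sulfur but exchanges one bicycle for a linked pair of rings: 5-(thiophen-3-yl)thiophen-2-yl in place of 1-benzothiophen-2-yl on a sulfonyl sulfur. Within the data shown here, no measured pair mirrors this exchange; the step from compound 1 to compound 2 concerns a change of attachment rather than of the aromatic part itself, so it offers only the observation that compound 2 sits well above compound 1 and gives no direction for compound 3.

On that basis compound 3 is expected to stay close to compound 2 in this assay, with the step of a 1.2-fold lower number from compound 2 to compound 3 (0.08 log units; within the scatter) estimated to lie within the scatter. The estimated value for compound 3 is 1500 nM, with a range from 450 nM to 5000 nM.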

Compound 3, half-maximal inhibitory concentration: 210 nM
The estimate for compound 3 lay 7.1-fold (0.85 log units) above the measured number; measured number outside the range, below it.
By their numbers in this assay, from the lowest: compounds 1 and 3 (each within the scatter of the next); then compound 2.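

In this assay, 5-(thiophen-3-yl)thiophen-2-yl in place of 1-benzothiophen-2-yl on a sulfonyl sulfur gives an 8.6-fold lower number from compound 2 to compound 3 (0.93 log units; beyond the scatter), so at this position the number depends strongly on which aromatic group is attached directly, and not only on the attachment. The comparison with the thienylmethyl compound gives a 1.1-fold higher number from compound 1 to compound 3 (0.02 log units; within the scatter) and lies within the scatter, so a directly attached aromatic group can match the (thiophen-2-yl)methyl group here, and the high number of compound 2 cannot be read as a general penalty for direct attachment. Nothing at hand bears on why two directly attached groups that differ in this way, a six-membered aromatic ring of carbon only in one and a second five-membered aromatic ring in the other, stand so far apart.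

Still open, as far as these compounds go, is how a longer chain on the sulfonyl sulfur, in place of the (thiophen-2-yl)methyl group, would read in this assay alongside these compounds. Equally open, from the compounds shown here alone, is what a phenyl group in place of the thiophen-3-yl ring, or an amine or a carboxylic acid carried on it, would do to the number.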